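The compounds below may be only part of what the source reports. "The series", "measured", "known", "first", "only" and "open" are said of these compounds alone.

Measured compounds in this series:
compound 1 `C[C@H](NC(=O)c1cc(C(F)(F)F)nn1C)c1nc(-c2cccc(F)c2)no1`, in an assay on T-REx-293 cells for inhibition of potassium channel subfamily T member 1 (Homo sapiens), read by patch clamp (on this read-out higher numbers stand for weaker inhibition and lower numbers for stronger inhibition), compound 1 gives 136 nM
compound 2 `Cc1cncc(-c2noc([C@H](C)NC(=O)c3cc(C(F)(F)F)nn3C)n2)c1`, in this assay compound 2 gives 1370 nM
compound 3 `C[C@H](NC(=O)c1cc(C(F)(F)F)nn1C)c1nc(-c2ccnc(N(C)C)c2)no1`, in this assay compound 3 gives 454 nM

Compound 3 stands second highest of the three numbers: the step of a 3.3-fold higher number from compound 1 to compound 3 (0.52 log units; beyond the scatter) places it beyond the scatter from compound 1, and the step of a 3.0-fold lower number from compound 2 to compound 3 (0.48 log units; beyond the scatter) places it beyond the scatter from compound 2, so it sits between the two.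

Compound 4 `CO[C@@H](C)c1cc(-c2noc([C@H](C)NC(=O)c3cc(C(F)(F)F)nn3C)n2)ccn1` differs from compound 3 in one place: 1-methoxyethyl in place of dimethylamino on an aromatic carbon. For the measured compounds named here, no measured step exchanges one substituent for another on the same six-membered ring; all three measured steps swap the whole aromatic group. Their sizes, a 10-fold higher number from compound 1 to compound 2 (1.00 log units; beyond the scatter) and the two steps given above, show that changes of this group move the number by modest amounts only, and every aromatic group measured so far stays within a single order of magnitude. The replacement of dimethylamino by 1-methoxyethyl, both carrying one hydrogen-bond acceptor and no charge, is therefore expected to give a step of at most modest size in this assay, with no firm direction from the data.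

The estimated step is a 1.1-fold higher number from compound 3 to compound 4 (0.04 log units; within the scatter). Compound 4 is expected to give about 500 nM, within the range 200 nM to 1500 nM.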

Compound 4, half-maximal inhibitory concentration: 744 nM
The estimate for compound 4 lay 1.5-fold (0.17 log units) below the measured number, and the stated range covers the measured number.
By their numbers in this assay, from the lowest: compound 1; then compounds 3, 4 and 2 (each within the scatter of the next, the first and the last beyond it).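

In this assay, for the compounds shown here, 1-methoxyethyl in place of dimethylamino, on an aromatic carbon next to the ring nitrogen, is the only measured exchange of one substituent for another on this six-membered ring (a 1.6-fold higher number from compound 3 to compound 4 (0.21 log units; within the scatter)), and the read-out does not separate the two groups, even though the entering group has oxygen where the leaving group has nitrogen and carries a defined stereocentre. Compared with the 5-methylpyridin-3-yl group, the new aromatic group also stays inside the scatter (a 1.8-fold lower number from compound 2 to compound 4 (0.27 log units; within the scatter)), whereas compared with 3-fluorophenyl it does not (a 5.5-fold higher number from compound 1 to compound 4 (0.74 log units; beyond the scatter)), so all three nitrogen-containing aromatic groups measured remain apart from 3-fluorophenyl. No measurement shown accounts for these numbers.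

The compounds shown leave open how a pyrrolidin-1-yl amine, a carboxylic acid or a longer ether chain would read at this same carbon. They also leave open whether the defined stereocentre of 1-methoxyethyl matters, and whether any substituent at this place can close the gap to compound 1.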